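The source may report more compounds than this note shows. Statements on the series, on what has been measured and on what is new or still open speak of the compounds shown alone.

Measured in an ADME assay on microsomes from liver (Mus musculus) for metabolic stability, read by LC-MS, with NADPH named in the record, with a stated time of 60 min, tested at 1 uM, in the absence of a further agent; on this read-out higher numbers stand for a more stable compound and lower numbers for a less stable compound (each value is a limit of the assay)
- Compound 1 `COc1ccc(-c2c(C)nc3c(N4CC[C@@H](NC(=O)C(F)(F)F)C4)cc(C)nn23)cc1OC` gives > 95% as a limit
- Compound 2 `COc1ccc(-c2c(C)nc3c(N4CC[C@@H](NC(=O)COc5ccccc5)C4)cc(C)nn23)cc1OC` gives > 95% as a limit
- Compound 3 `COc1ccc(-c2c(C)nc3c(N4CC[C@@H](NC(=O)NC(C)C)C4)cc(C)nn23)cc1OC` gives > 95% as a limit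

Compound 3 is known only through the limit > 95% and has no number. Compound 4 `COc1ccc(-c2c(C)nc3c(N4CC[C@@H](NC(=O)OC5CCCCC5)C4)cc(C)nn23)cc1OC` carries cyclohexyloxy in place of isopropylamino on a carbonyl carbon. Changes on that carbonyl carbon are seen in a step that the two limits leave unreadable from compound 1 to compound 2 and a step that the two limits leave unreadable from compound 1 to compound 3 and also a step that the two limits leave unreadable from compound 2 to compound 3 so no size carries over. Among the compounds with values here, the only guide in this assay is the limit of > 95% in this assay, at which 3 of the 3 values shown sit, and no step beyond the scatter is expected, though any real move could only be downward. The expected change is a number at least 5 percentage points lower from compound 3 to compound 4 (that floor lies within the scatter) as an estimate. For compound 4 the estimate is 90% with an expected range from 70% to 100% in this read-out.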

Compound 4, percent of the compound remaining: > 95%
Compound 4: a limit, no number (the forecaster's own chance of this, stated with the estimate: 50%); at least 5 percentage points between middle value and limit.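

Compound 4 gives > 95%, which is a limit, so the steps to it from compound 1, compound 2 and compound 3 cannot be read. Whether the groups on the carbonyl carbon differ at all in stability stays open: the limit of > 95% in this assay, at which 4 of the 4 values shown sit.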